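This account rests on a few compounds, and the source may have more. Where it says the series, first, only, none or still open, it means among the compounds named here.

Among the compounds with values here, only two compounds in this small set give a number in a functional assay on MDA-MB-231 cells (Homo sapiens) for antiproliferative activity, read by MTT assay, with a stated time of 24 h; on this read-out lower numbers stand for stronger inhibition and higher numbers for weaker inhibition. Compound 2 `O=C(O)CC(NC(=O)c1ccc(F)cc1)c1ccc(Cl)cc1Cl` gives 58300 nM, and compound 3 `O=C(O)CC(NC(=O)c1cccc(Br)c1)c1ccc(Cl)cc1Cl` gives 82500 nM. These two values lie within the usual scatter of each other, so compound 3 cannot be ranked against compound 2. In this assay compound 1 `CC(C)(C)c1ccc(C(CC(=O)O)NS(=O)(=O)c2ccc(OC(F)(F)F)cc2)cc1` gives only a limit, > 100000 nM.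

Compound 4 `COc1ccc(C(=O)NC(CC(=O)O)c2ccc(Cl)cc2Cl)cc1` keeps the core of compound 3 and changes one group: 4-methoxyphenyl in place of 3-bromophenyl on a carbonyl carbon. Within the data shown here, only one measured step bears on this change, because it also exchanges the group on that carbonyl carbon: a 1.4-fold higher number from compound 2 to compound 3 (0.15 log units; within the scatter). That step is small and stays within the scatter. Among the measured compounds shown here, it is thin support, since it is a single step and no measured compound carries 4-methoxyphenyl.

Resting on that step, a shift beyond the scatter is not expected, and no clear direction can be called. The estimated move is a 1.2-fold lower number from compound 3 to compound 4 (0.07 log units; within the scatter). For compound 4 the estimated value is 70000 nM, with an expected range from 30000 nM to 130000 nM.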

Compound 4, half-maximal inhibitory concentration: > 100000 nM
Compound 4: no number, only a limit; the forecaster's own chance of this, stated with the estimate: 20%; at least 1.4-fold (0.15 log units) between middle value and limit.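

In this assay, within the data shown here, compound 4, which carries 4-methoxyphenyl on the carbonyl carbon, gives only a limit, > 100000 nM, and it is the one compound on this shared core without an exact number. Against the two exact numbers on this core, that limit yields only floors: an at least 1.2-fold higher number from compound 3 to compound 4 (0.08 log units; that floor lies within the scatter), and, read as methoxy in place of fluoro on an aromatic carbon, an at least 1.7-fold higher number from compound 2 to compound 4 (0.23 log units; that floor lies within the scatter). With 4-fluorophenyl, 3-bromophenyl and 4-methoxyphenyl now seen on this carbonyl carbon, no step among the three compounds is yet shown to lie beyond the scatter, and the new reading stops at a limit: the limit of > 100000 nM in this assay, at which 2 of the 4 values shown sit.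

As far as these compounds go, how far the true value of compound 4 lies past its limit remains unknown, so its place relative to compound 2 and compound 3 cannot be settled. The compounds shown also leave open what a different kind of group would do on this carbonyl carbon, such as a phenyl ring bearing an amine or a carboxylic acid, or a longer chain in place of the ring.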